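Hydrogen in place of methoxy: compound 1 to compound 4

A few compounds are considered here, and "the series" means these few. Any claim that something is new, unique, unknown or untested is made for them only; others in the source may bear on it.

Measured so far:
- compound 1 `COc1ccc(/C=C/C(=O)/C=C/c2ccc(OCc3cn(CCCCOc4cc(=O)oc5ccccc45)nn3)c(OC)c2)cc1OC` gives "not active" (no number reported)
- compound 2 `COc1cc(/C=C/C(=O)/C=C/c2cccs2)ccc1OCc1cn(CCOc2cc(=O)oc3ccccc23)nn1` gives 12%
- compound 3 `COc1ccc(/C=C/C(=O)/C=C/c2ccc(OCc3cn(CCCCCOc4cc(=O)oc5ccccc45)nn3)c(OC)c2)cc1` gives "not active" (no number reported)

In a functional assay on PC-3 cells (Homo sapiens) for inhibition, read by sulforhodamine B assay, with a stated time of 48 h, tested at 50 uM (on this read-out higher numbers stand for more inhibition of growth at the one concentration tested and lower numbers for less inhibition of growth), compound 1 gives "not active" (no number reported) and so has no single number, an outcome shared with compound 3. Compound 4 `COc1ccc(/C=C/C(=O)/C=C/c2ccc(OCc3cn(CCCCOc4cc(=O)oc5ccccc45)nn3)c(OC)c2)cc1` differs from compound 1 by one change (hydrogen in place of methoxy on an aromatic carbon), hydrogen in place of methoxy on an aromatic carbon, which turns 3,4-dimethoxyphenyl into 4-methoxyphenyl. Within the data shown here, no measured pair shows this change. No step beyond the scatter is expected in this assay, since compound 2 gives only 12% and compound 3 gives "not active" (no number reported) in the same read-out. For compound 4 the estimated value is 8%, within an expected range of 0% to 20%.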

Compound 4, percent growth inhibition at one concentration: "not active" (no number reported)
The entry for compound 4 holds no number; the estimate stays without a comparison.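

In this assay compound 4 gives "not active" (no number reported) and compound 1 gives "not active" (no number reported), so no step can be read between them. No evidence bears on this result. The compounds shown leave open whether removing this methoxy group changes growth inhibition at all.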